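The source may report more compounds than this note shows. Statements on the series, on what has been measured and on what is new or still open speak of the compounds shown alone.

Measured compounds:
compound 1 `CCCCCCCC(=O)Nc1ccc2[nH]cc(C3CCN(C)CC3)c2n1`; in an assay for binding affinity to 5-hydroxytryptamine receptor 1B (Homo sapiens), read by radioligand binding (a higher number here means a weaker inhibitor, a lower number a stronger inhibitor), compound 1 gives 32 nM.
compound 2 `Cc1cccc(C(=O)Nc2ccc3[nH]cc(C4CCN(C)CC4)c3n2)c1`; compound 2 gives 1200 nM.
compound 3 `CN1CCC(c2c[nH]c3ccc(NC(=O)c4ccc(C#N)cc4)nc23)CC1`; compound 3 gives 310 nM.

Compound 3 stands second highest of the three numbers. Its nearest neighbour is compound 2, with a 3.9-fold lower number from compound 2 to compound 3 (0.59 log units; beyond the scatter); the furthest is compound 1, with a 9.7-fold higher number from compound 1 to compound 3 (0.99 log units; beyond the scatter).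

Compound 4 `CN1CCC(c2c[nH]c3ccc(NC(=O)c4ccncc4)nc23)CC1` is not yet measured. It differs from compound 3 in one place: pyridin-4-yl in place of 4-cyanophenyl on a carbonyl carbon.

All three measured steps change the group on the carbonyl carbon, so all bear on this one, though none exchanges an aromatic ring for a pyridin-4-yl. a 38-fold higher number from compound 1 to compound 2 (1.57 log units; beyond the scatter) is the large step; a 9.7-fold higher number from compound 1 to compound 3 (0.99 log units; beyond the scatter) is modest. Among the compounds with values here, the closest precedent is a 3.9-fold lower number from compound 2 to compound 3 (0.59 log units; beyond the scatter), an exchange of one six-membered aromatic ring for another, which gave a modest step. The step from compound 3 to compound 4 is therefore expected to be modest at most, and its direction is not fixed by the data; the estimate is placed near compound 3, as a 1.6-fold higher number from compound 3 to compound 4 (0.21 log units; within the scatter). Compound 4 is thus expected to give about 500 nM in this assay, within a range from 150 nM to 2000 nM.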

Compound 4, inhibition constant: 330 nM
The estimate for compound 4 lay 1.5-fold (0.18 log units) above the measured number, and the stated range covers the measured number.
By their numbers in this assay, from the lowest: compound 1; then compounds 3 and 4 (each within the scatter of the next); then compound 2.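

In this assay, the exchange of 4-cyanophenyl for pyridin-4-yl on the carbonyl carbon gives a 1.1-fold higher number from compound 3 to compound 4 (0.03 log units; within the scatter), so removing the triple bond and placing a nitrogen in the six-membered aromatic ring leaves the number effectively unchanged. Compound 4 also keeps the standing of the nitrile-bearing compound 3 against the other two groups, with a 3.6-fold lower number from compound 2 to compound 4 (0.56 log units; beyond the scatter) and a 10-fold higher number from compound 1 to compound 4 (1.01 log units; beyond the scatter), so neither gap depends on the nitrile itself, and all three aromatic groups shown give higher numbers than heptyl, with no exception among these compounds. No measurement shown accounts for the match between the 4-cyanophenyl and pyridin-4-yl compounds.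

Still open, going by these compounds, is whether the distance of 3-methylphenyl from these two groups reflects the methyl group, its place on the ring or both, which 4-methylphenyl, pyridin-3-yl or unsubstituted phenyl on the same carbonyl carbon could help to separate. Also open, on these data alone, is how much of the lower number for heptyl depends on chain length, a question for butyl and decyl chains, or for a cyclohexyl ring as a non-aromatic counterpart to the aromatic groups.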